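The source may hold more compounds than are shown below. What is called first, only, known or untested is meant among the compounds shown, and "the series" means these compounds.

Compound 1 `CCCOC(=O)NC(=O)c1ccsc1NC(=O)c1ccc(S(=O)(=O)N2CCCCC2)cc1`: 56.6 ug/mL
Compound 2 `O=C(NC(=O)c1ccsc1NC(=O)c1ccc(S(=O)(=O)N2CCCCC2)cc1)OCC(F)(F)F`: "nd" (no result reported)
Compound 3 `O=C(Nc1sccc1C(=O)Nc1ccccn1)c1ccc(S(=O)(=O)N2CCCCC2)cc1`: "nd" (no result reported)

These compounds were tested in a toxicity assay on Vero cells (Chlorocebus sabaeus) for cytotoxicity, read by MTT assay; a higher number here means a weaker inhibitor, a lower number a stronger inhibitor. Only compound 1 has a number, at 56.6 ug/mL. No result is reported for compound 3, so it has no place on the scale, and the same is true of compound 2. Compound 4 `Cc1ccnc(NC(=O)c2ccsc2NC(=O)c2ccc(S(=O)(=O)N3CCCCC3)cc2)n1` is still to be measured. The structural change is 4-methylpyrimidin-2-yl in place of pyridin-2-yl on an amide-type nitrogen, which puts 4-methylpyrimidin-2-yl in place of pyridin-2-yl on an amide-type nitrogen. The rest of the molecule stays the same. Going by the values given here, no pair of measured compounds shows what a change of this kind does, so the data offer no direct guide. The expectation is therefore a modest one: no step beyond the scatter, and no favoured direction. Among the compounds with values here, the only anchor is compound 1 at 56.6 ug/mL, which carries a different group on the same shared core, so the range must stay wide. For compound 4 the estimated value in this assay is 45 ug/mL, with an expected range from 14 ug/mL to 140 ug/mL.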

Compound 4, half-maximal inhibitory concentration: 32.8 ug/mL
Estimate against measurement, compound 4: 1.4-fold (0.14 log units) above; the range from low to high includes it.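

In this assay the amide-type nitrogen now carries two very different groups that each have a number, and swapping propoxycarbonyl for 4-methylpyrimidin-2-yl gives a small step (a 1.7-fold lower number from compound 1 to compound 4 (0.24 log units; within the scatter)). This shows that, for this one pair, a six-membered aromatic ring with 2 hetero atoms and an open-chain carbamate-type group cannot be told apart in this read-out. Nothing measured here bears on why the two groups read alike.

The change from pyridin-2-yl to 4-methylpyrimidin-2-yl itself, like any step involving compound 2, cannot be read, since compound 3 and compound 2 have no result. Still open, as far as these compounds go, is how a pyrimidin-2-yl group without the methyl, or a phenyl ring or a carboxylic acid on the same nitrogen, would read on this scale.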